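The source may report more compounds than this note shows. Statements on the series, on what has been measured and on what is new or still open speak of the compounds shown alone.

Measured compounds in a functional assay on A549 cells (Homo sapiens) for cytotoxicity, read by MTT assay, with a stated time of 2 days; on this read-out higher numbers stand for weaker inhibition and lower numbers for stronger inhibition:
compound 1 `c1ccc(CO/N=C2/C(c3c[nH]c4ccccc34)=Nc3ccccc32)cc1` gives 19300 nM
compound 2 `Cc1ccc(CO/N=C2/C(c3c[nH]c4ccc(Br)cc34)=Nc3ccc(Br)cc32)cc1` gives 13300 nM
compound 3 `FC(F)(F)c1ccc(CO/N=C2/C(c3c[nH]c4ccc(Br)cc34)=Nc3ccc(Br)cc32)cc1` gives 8450 nM

Compound 1 shows the highest of the three numbers; compound 2 sits within the scatter of it, and compound 3 lies beyond the scatter below it. Compound 4 `Fc1ccc(CO/N=C2/C(c3c[nH]c4ccccc34)=Nc3ccccc32)c(Cl)c1` differs from compound 1 in one place: 2-chloro-4-fluorophenyl in place of phenyl on a saturated chain carbon bound to an oxygen on an unsaturated carbon. For the measured compounds named here, the only measured step on this part of the molecule is a 1.6-fold lower number from compound 2 to compound 3 (0.20 log units; within the scatter), which is within the scatter. Going by the values given here, compounds 2 and 3 also carry two bromines on the shared core, so no step from compound 1 to either of them is counted. The expectation for compound 4 is therefore a small step in this assay, if any, downward: a 1.4-fold lower number from compound 1 to compound 4 (0.14 log units; within the scatter). Compound 4 is estimated at 14000 nM, with a range from 6000 nM to 32000 nM.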

Compound 4, half-maximal inhibitory concentration: 21400 nM
Beside the measured number, compound 4's estimate is 1.5-fold (0.18 log units) below it; the range from low to high includes it.
By their numbers in this assay, from the lowest: compounds 3, 2, 1 and 4 (each within the scatter of the next, the first and the last beyond it).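

In this assay, 2-chloro-4-fluorophenyl in place of phenyl on the saturated chain carbon comes to a 1.1-fold higher number from compound 1 to compound 4 (0.04 log units; within the scatter). Unlike the step between compound 2 and compound 3, this one is read on the core without bromines, and it shows that the chlorine and fluorine together leave the number within the scatter of compound 1. No measured evidence at hand speaks to this result.

From the compounds shown here alone, it remains open whether an amine or a carboxylic acid on this phenyl ring would move the number beyond the scatter. Going by these compounds, it is also open whether 2-chloro-4-fluorophenyl would behave alike on the core carrying two bromines.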